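The compounds below may be only part of what the source reports. "The series", "measured", "known", "first", "only" and "open" are said of these compounds alone.

Compound 1 `ClCc1ccccc1Cn1cnc2c(Cl)nc(Cl)nc21`: 2810 nM
Compound 2 `ClCc1cccc(Cn2cnc3ncnc(Cl)c32)c1`: 14500 nM
Compound 3 `ClCc1cccc(Cn2cnc3nc(Cl)nc(Cl)c32)c1`: 2630 nM

Three compounds share a fused two-ring core carrying a benzyl group with a chloromethyl substituent, and have been tested in a functional assay on M14 cells (Homo sapiens) for cytotoxicity, read by sulforhodamine B assay, with a stated time of 48 h; a higher number here means a weaker inhibitor of growth, a lower number a stronger inhibitor of growth. Compound 1 gives the second highest of the three numbers; its nearest neighbour is compound 3, whose number is within the scatter of it, while compound 2 lies well above both.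

Compound 4 `Nc1nc(Cl)c2ncn(Cc3ccccc3CCl)c2n1` is the next step from compound 1: amino in place of chloro on an aromatic carbon. Within the data shown here, no measured pair changes chloro to amino. Among the measured compounds shown here, the one step that touches the same position, a 5.5-fold lower number from compound 2 to compound 3 (0.74 log units; beyond the scatter), shows that taking chloro away (leaving hydrogen) makes the number rise by a modest amount. Whether amino behaves like hydrogen or like chloro at this place cannot be told from these three compounds, so the expectation is loose and leans toward a somewhat higher number.

For compound 4 the expected value in this assay is 6000 nM, within a range of 2000 nM to 20000 nM, which corresponds to an estimated step of a 2.1-fold higher number from compound 1 to compound 4 (0.33 log units; beyond the scatter).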

Compound 4, concentration for total growth inhibition: 39800 nM
For compound 4 the middle estimate is 6.6-fold (0.82 log units) below the measured one; the measured number lies above the stated range.
By their numbers in this assay, from the lowest: compounds 3 and 1 (each within the scatter of the next); then compound 2; then compound 4.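

In this assay, amino in place of chloro on this aromatic carbon between two ring nitrogen atoms gives a 14-fold higher number from compound 1 to compound 4 (1.15 log units; beyond the scatter) and so a much weaker inhibitor of growth. Until now this place had been read only through chloro and hydrogen, in a 5.5-fold lower number from compound 2 to compound 3 (0.74 log units; beyond the scatter) and the new result adds a third group, showing that amino does not preserve the activity seen with chloro in this pair. Nothing measured here explains why this change has so large an effect.

Going by these compounds, it remains open whether a methoxy group, a methylamino group or a longer chain at this place would behave more like amino or like chloro. Also open, on these data alone, is whether amino would have an effect of similar size with the chloromethyl group placed as in compound 3.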